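The compounds below may be only part of what the source reports. "The series", "measured", "known", "first", "only" and "open" are said of these compounds alone.

Measured in a functional assay on ACHN cells (Homo sapiens) for antiproliferative activity, read by sulforhodamine B assay; a higher number here means a weaker inhibitor of growth, a lower number a stronger inhibitor of growth:

Compound 1 `CC(C)(C)CCOc1cccc(O)c1C(=O)/C=C/c1ccc(C(=O)O)cc1`: 8450 nM
Compound 2 `CCCCCCOc1cccc(O)c1C(=O)/C=C/c1ccc(O)cc1`: > 30000 nM

Only compound 1 has a numerical result. Compound 2 stands at > 30000 nM, which is a limit of the assay and not a number.

Compound 3 `CC(C)=CCOc1cccc(O)c1C(=O)/C=C/c1ccc(O)cc1` has not yet been measured in this assay. It carries 2-methylprop-1-en-1-yl in place of pentyl on a saturated chain carbon bound to an oxygen on an aromatic ring. Cut one bond further out, the same change reads hexyloxy to (3-methylbut-2-en-1-yl)oxy. Going by the values given here, no measured pair shows a change of this kind, and the starting point is only a limit. The expectation is therefore for no shift beyond the usual scatter, with growth inhibition remaining weak. The estimated change is an at least 1.0-fold lower number from compound 2 to compound 3 (0.02 log units; that floor lies within the scatter). For compound 3 the expected value is 28000 nM, with an estimated range of 12000 nM to 50000 nM.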

Compound 3, concentration for 50% growth inhibition: > 30000 nM
Compound 3 was reported as a limit (the forecaster's own chance of this, stated with the estimate: 55%); at least 1.0-fold (0.02 log units) between middle value and limit.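

Compound 2 and compound 3 both stand at a limit and not at a number, so no step between them can be read: the limit of > 30000 nM in this assay, at which 2 of the 3 values shown sit.

The compounds shown leave open whether hexyloxy and (3-methylbut-2-en-1-yl)oxy differ at all in their effect on growth.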